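Phenyl in place of methyl on a substituted pyridone amide

The source may hold more compounds than are shown below. What is called first, only, known or untested is meant among the compounds shown, and "the series" means these compounds.

Compound 1 `O=C(NC1CCCCCC1)c1c(-c2ccccc2)c(Br)cn(Cc2ccc(F)cc2)c1=O` — an assay on HEK293 cells for inhibition of Lysophosphatidylserine lipase ABHD12 (Homo sapiens), with stated times of 30 min and 5 min; a higher number here means a weaker inhibitor, a lower number a stronger inhibitor: > 10000 nM
Compound 2 `COc1ccc(-c2cn(Cc3ccc(F)cc3)c(=O)c(C(=O)NC3CCCCCC3)c2-c2ccccc2)cc1` — this assay: > 10000 nM
Compound 3 `Cc1c(-c2ccccc2)cn(Cc2ccc(F)cc2)c(=O)c1C(=O)NC1CCCCCC1` — this assay: 2500 nM

Of the compounds shown here, three sharing one core have been measured. In this assay compound 1 gives only a limit, > 10000 nM. In this assay compound 2 likewise reaches only a limit, > 10000 nM. For the measured compounds named here, compound 3 is the one compound with an actual number, 2500 nM in this assay, so it stands as the sole readable point. The step from compound 1 to compound 2 a step that the two limits leave unreadable from compound 1 to compound 2 cannot be sized because both ends sit at the limit of > 10000 nM in this assay, at which 2 of the 3 values shown sit.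

Compound 4 `O=C(NC1CCCCCC1)c1c(-c2ccccc2)c(-c2ccccc2)cn(Cc2ccc(F)cc2)c1=O` is not yet measured. Its change from compound 3 is phenyl in place of methyl on an aromatic carbon. The bearing evidence is thin: the 4-methoxyphenyl of compound 2 resembles the phenyl entering compound 4, and compound 2 sat at the limit, while compound 3 with its methyl gave a number. A loss of potency is therefore expected in this assay, with a fair chance that only a limit is reported. The expected step from compound 3 to compound 4 is a 3.2-fold higher number from compound 3 to compound 4 (0.51 log units; beyond the scatter). Compound 4 is estimated at 8000 nM, within 2500 nM to 30000 nM.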

Compound 4, half-maximal inhibitory concentration: > 10000 nM
Compound 4: no number, only a limit (the forecaster's own chance of this, stated with the estimate: 55%); middle value at least 1.2-fold (0.09 log units) away from the limit.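

At the aromatic carbon opposite the ring nitrogen, compound 4 gives the first readable step: in this assay, phenyl in place of methyl brings an at least 4.0-fold higher number from compound 3 to compound 4 (0.60 log units; beyond the scatter). The earlier compounds shown here showed only limits for bromo and 4-methoxyphenyl at this carbon, and the result now shows that an unsubstituted phenyl also fails to keep a measurable value, so the methoxy group of compound 2 is not needed for that outcome. The steps among compound 1, compound 2 and compound 4 cannot be read, so bromo, phenyl and 4-methoxyphenyl cannot be ranked against one another: the limit of > 10000 nM in this assay, at which 3 of the 4 values shown sit.

The compounds shown leave open whether any group at this carbon improves on the methyl of compound 3, which gives 2500 nM in this assay, and hydrogen, ethyl or cyclopropyl would each test that. They also leave open whether an aromatic ring is what matters here or whether a saturated ring such as cyclohexyl would end at the same limit.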